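Trimethoxyphenyl pyrazole chalcones: aryl ketone swap

This account rests on a few compounds, and the source may have more. Where it says the series, first, only, none or still open, it means among the compounds named here.

Measured compounds:
compound 1, `COc1cc(-c2cc(/C=C/C(=O)c3ccc(N)cc3)[nH]n2)cc(OC)c1OC`: 95%
compound 2, `COc1cc(C(=O)/C=C/c2cc(-c3cc(OC)c(OC)c(OC)c3)n[nH]2)cc(OC)c1OC`: 96%

Both measured members of the series were read in a functional assay on NCI-H322M cells (Homo sapiens) for cytotoxicity, read by sulforhodamine B assay, with a stated time of 48 h, tested at 0.01 uM; on this read-out lower numbers stand for a stronger effect and higher numbers for a weaker effect at the one concentration tested. Compound 1 gives 95% and compound 2 gives 96%; the two numbers lie within the scatter of each other, so compound 1 stands at the same level as compound 2, and neither shows more than a marginal effect at the concentration used.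

Compound 3, `COc1cc(-c2cc(/C=C/C(=O)c3ccc(F)c(F)c3)[nH]n2)cc(OC)c1OC`, is the untested analogue. Its difference from compound 1 is 3,4-difluorophenyl in place of 4-aminophenyl on a carbonyl carbon. For the measured compounds named here, no step between measured compounds is available to calibrate this exchange. Given that compound 1 gives 95% and compound 2 gives 96%, the expectation is a step of a number 3 percentage points lower from compound 1 to compound 3 (within the scatter) that stays within the scatter, if anything a little downward. For compound 3 the estimated value in this assay is 92%, with a range from 78% to 104%.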

Compound 3, a percentage reported as activity, at one concentration (the size of the read-out at that concentration, not a potency): 94%
The estimate for compound 3 lay 2 percentage points below the measured number; the measured number falls inside the stated range.
By their numbers in this assay, from the lowest: compounds 3, 1 and 2 (each within the scatter of the next).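

In this assay, for the compounds shown here, 3,4-difluorophenyl in place of 4-aminophenyl on a carbonyl carbon gives a number 1 percentage points lower from compound 1 to compound 3 (within the scatter), the first step that isolates a change in one place. The exchange removes the hydrogen-bond donor and acceptor counted on 4-aminophenyl, yet the read-out at this one concentration does not move beyond the scatter, so this position shows no sensitivity to this particular change under these conditions. No measured evidence bears on why the number holds steady here.

From the compounds shown here alone, whether a carboxylic acid or a morpholine on the same carbonyl carbon would shift the number beyond the scatter remains open. Also open, going by these compounds, is whether the two aryl groups would separate at a higher concentration, since a single concentration with so marginal an effect gives little room for a difference to show.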